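A few compounds are considered here, and "the series" means these few. Any claim that something is new, unique, unknown or untested is made for them only; others in the source may bear on it.

Among the measured compounds shown here, in a functional assay on A549 cells (Homo sapiens) for inhibition, read by MTT assay, with a stated time of 48 h (a lower number here means a stronger inhibitor, a higher number a weaker inhibitor), compound 3 `COc1ccc(N(C)c2nc(C)nc3ccccc23)cc1[Se]C#N` gives 49 nM, the lowest of the three numbers measured so far. Compound 1 `COc1ccc(N(C)c2nc(C)nc3ccccc23)cc1C(=O)NCC[Se]C#N` gives 187 nM and compound 2 `COc1ccc(N(C)c2nc(C)nc3ccccc23)cc1OCCCC[Se]C#N` gives 1200 nM. Compound 4 `COc1ccc(N(C)c2nc(C)nc3ccccc23)cc1C[Se]C#N` has not yet been measured. Its difference from compound 3 is a group of 4 heavy atoms (2 carbon, 1 nitrogen, 1 selenium; no ring) in place of a group of 3 heavy atoms (1 carbon, 1 nitrogen, 1 selenium; no ring), on an aromatic carbon, on an aromatic carbon of a six-membered aromatic ring of carbon only, ortho to a methoxy group.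

For the measured compounds named here, two measured steps bear on this change, both at the same place and both shortening the group: a 3.8-fold lower number from compound 1 to compound 3 (0.58 log units; beyond the scatter), which is modest, and a 24-fold lower number from compound 2 to compound 3 (1.39 log units; beyond the scatter), which is large. Read in reverse, each means a higher number for the larger group, and none of the three compounds goes against this. The group size alone does not settle the number, however: compounds 1 and 2 carry groups of equal heavy-atom count, yet a 6.4-fold higher number from compound 1 to compound 2 (0.81 log units; beyond the scatter). Going by the values given here, no measured step is as small as the present one, so the size of the change remains uncertain.

A modest move towards weaker inhibition is expected, smaller than the step separating compound 1 from compound 3. The estimated step is a 2.2-fold higher number from compound 3 to compound 4 (0.35 log units; beyond the scatter). For compound 4 the estimated value is 110 nM, with an expected range of 35 nM to 350 nM.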

Compound 4, half-maximal inhibitory concentration: 98 nM
The estimate for compound 4 lay 1.1-fold (0.05 log units) above the measured number; the range from low to high includes it.
By their numbers in this assay, from the lowest: compounds 3, 4 and 1 (each within the scatter of the next, the first and the last beyond it); then compound 2.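

In this assay, the smallest change at this position, the group of 4 heavy atoms in place of the group of 3 heavy atoms on the aromatic carbon ortho to a methoxy group, gives a 2.0-fold higher number from compound 3 to compound 4 (0.30 log units; within the scatter) and so shows that this short extension does not clearly shift the number. The group of 8 heavy atoms carrying the amide is also not clearly separated from the new group, with a 1.9-fold lower number from compound 1 to compound 4 (0.28 log units; within the scatter) as its step, while the group of 8 heavy atoms carrying the ether oxygen stands well apart, with a 12-fold lower number from compound 2 to compound 4 (1.09 log units; beyond the scatter) as a large step, so at this position the earlier link between a larger group and a higher number no longer holds for every pair. No measured data bear on why these groups differ as they do.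

The compounds shown all keep the selenium and nitrile unit, so what a sulfur atom in place of the selenium, or a simple amine or carboxylic acid at this position, would give remains open. Also open, going by these compounds, is how the number runs with a longer chain of carbon atoms alone, without an amide or an ether oxygen in it.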